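Compound 2 to compound 4: swapping one side chain

The compounds below may be only part of what the source reports. "The series", "measured", "known", "first", "only" and "open" are said of these compounds alone.

Measured in a functional assay on DU-145 cells (Homo sapiens) for cytotoxicity, read by MTT assay; on this read-out higher numbers stand for weaker inhibition and lower numbers for stronger inhibition:
- compound 1 `CCCC(O)CC(=O)O[C@H](CC=C(C)C)C1=CC(=O)c2c(O)ccc(O)c2C1=O`: > 100000 nM, a limit and not a number
- compound 2 `CC(=O)OCCC(=O)O[C@H](CC=C(C)C)C1=CC(=O)c2c(O)ccc(O)c2C1=O`: 15700 nM
- compound 3 `CCCCC(CC(=O)O[C@H](CC=C(C)C)C1=CC(=O)c2c(O)ccc(O)c2C1=O)OC(C)=O`: 67700 nM

Compound 2, at 15700 nM, holds the lower of the two exact numbers. The other exact number sits higher, with a 4.3-fold higher number from compound 2 to compound 3 (0.63 log units; beyond the scatter).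

Compound 4 `CCC(O)CO[C@H](CC=C(C)C)C1=CC(=O)c2c(O)ccc(O)c2C1=O` brings this change: 2-hydroxybutyl in place of (2-acetoxyethyl)carbonyl on an oxygen on a saturated carbon. Here 2-hydroxybutyl stands in place of (2-acetoxyethyl)carbonyl on an oxygen on a saturated carbon.

For the measured compounds named here, no measured step alters this oxygen directly. The closest guide is the swap of 1-hydroxybutyl for acetoxymethyl, which gave an at least 6.3-fold lower number from compound 1 to compound 2 (0.80 log units; beyond the scatter). As 2-hydroxybutyl also carries a hydroxyl, a modest rise is expected, read in reverse from that step. The expected change is a 2.5-fold higher number from compound 2 to compound 4 (0.41 log units; beyond the scatter). For compound 4 the estimated value is 40000 nM, with an expected range of 12000 nM to 100000 nM.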

Compound 4, half-maximal inhibitory concentration: 16400 nM
Compound 4: middle estimate off by 2.4-fold (0.39 log units), on the high side; the measured number falls inside the stated range.
By their numbers in this assay, from the lowest: compounds 2 and 4 (each within the scatter of the next); then compound 3. At a limit, above all of these: compound 1.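

Compound 4 shows that this oxygen can carry 2-hydroxybutyl in place of (2-acetoxyethyl)carbonyl with no change that stands out from the scatter, a 1.0-fold higher number from compound 2 to compound 4 (0.02 log units; within the scatter). A hydroxyl in this side chain therefore does not always go with the weak result of compound 1, which also carries one, an at least 6.0-fold lower number from compound 1 to compound 4 (0.78 log units; beyond the scatter). That step rests on a limit and not an exact number: the limit of > 100000 nM in this assay, at which 1 of the 4 values shown sits.

Still open, on these data alone, is how an amine or a carboxylic acid on this side chain would compare. A longer chain than 2-hydroxybutyl is also untested among the compounds shown here.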